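Replacing a diol tail with an anilinoethyl amide

This account rests on a few compounds, and the source may have more. Where it says the series, first, only, none or still open, it means among the compounds named here.

Compound 3 `Cc1c(C(=O)NCC(O)CO)oc2ccc(N(Cc3ccc(Br)cc3)S(=O)(=O)c3ccc(Br)cc3)cc12` carries the shared core with a (2,3-dihydroxypropyl)carbamoyl group. In a functional assay on HCT-116 cells (Homo sapiens) for antiproliferative activity, read by MTT assay, with a stated time of 48 h (a lower number here means a stronger inhibitor, a higher number a weaker inhibitor), compound 3 gives 27800 nM, the highest of the two numbers recorded; compound 1 `Cc1c(C(=O)OCCCN(C)C)oc2ccc(N(Cc3ccc(Br)cc3)S(=O)(=O)c3ccc(Br)cc3)cc12` is nearest with 11200 nM, the step being a 2.5-fold higher number from compound 1 to compound 3 (0.39 log units; beyond the scatter). Compound 2 `Cc1c(C(=O)NCCS(C)(=O)=O)oc2ccc(N(Cc3ccc(Br)cc3)S(=O)(=O)c3ccc(Br)cc3)cc12` shows only a limit, > 40000 nM, in this assay. Among the compounds with values here, the step of an at least 1.4-fold lower number from compound 2 to compound 3 (0.15 log units; that floor lies within the scatter) is the one change at the same place. Compound 4 `Cc1c(C(=O)NCCNc2ccccc2)oc2ccc(N(Cc3ccc(Br)cc3)S(=O)(=O)c3ccc(Br)cc3)cc12` differs from compound 3 by anilinomethyl in place of 1,2-dihydroxyethyl on a saturated chain carbon bound to an amide-type nitrogen. All measured changes at the amide end moved this assay only modestly, so compound 4 is expected to sit close to compound 3, with an expected step of a 1.9-fold lower number from compound 3 to compound 4 (0.27 log units; within the scatter). Compound 4 is estimated at 15000 nM, with a range of 5000 nM to 45000 nM.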

Compound 4, half-maximal inhibitory concentration: > 40000 nM
Compound 4 ended at the assay's limit (the forecaster's own chance of this, stated with the estimate: 20%); at least 2.6-fold (0.42 log units) between middle value and limit.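

The anilinomethyl group, with its six-membered aromatic ring, brought no readable gain over 1,2-dihydroxyethyl on this saturated chain carbon: the record is an at least 1.4-fold higher number from compound 3 to compound 4 (0.15 log units; that floor lies within the scatter). The (2-anilinoethyl)amino group also falls short of 3-(dimethylamino)propoxy on the carbonyl carbon, with an at least 3.5-fold higher number from compound 1 to compound 4 (0.55 log units; beyond the scatter), so all three amides shown give higher numbers than compound 1 in this assay. Compound 4 sits at a limit of the assay, as does compound 2, so the step between them cannot be read: the limit of > 40000 nM in this assay, at which 2 of the 4 values shown sit.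

On these data alone, it remains open whether a dimethylamino group on the amide chain would bring the number down. The same is open for a carboxylic acid at this place.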